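A few compounds are considered here, and "the series" means these few. Any claim that something is new, unique, unknown or untested is made for them only; others in the source may bear on it.

Compound 1, with the structure `COC(=O)[C@@]1(C)CCC=C2[C@@H]1CC[C@@H](C)[C@]2(C)Cc1c(C)[nH]c2ccc(Br)cc12`, was tested in a functional assay on SW1573 cells (Homo sapiens) for inhibition, read by sulforhodamine B assay, with a stated time of 48 h (on this read-out higher numbers stand for weaker inhibition of growth and lower numbers for stronger inhibition of growth), where compound 1 gives 14000 nM. Compound 2, `COC(=O)[C@@]1(C)CCC=C2[C@@H]1CC[C@@H](C)[C@]2(C)Cc1c(C)[nH]c2ccc(Cl)cc12`, differs from compound 1 in one place: chloro in place of bromo on an aromatic carbon. In this assay compound 2 gives 14000 nM, and the step of no change at the digits printed from compound 1 to compound 2 (within the scatter) shows that this exchange left the growth inhibition essentially unchanged.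

Compound 3, `COC(=O)[C@@]1(C)CCC=C2[C@@H]1CC[C@@H](C)[C@]2(C)Cc1c(C)[nH]c2c(Br)cccc12`, has the same atoms as compound 1 joined differently; the difference between the two cores is not broken down here. In this assay compound 3 gives 25000 nM, a value that sits within the usual scatter of compound 1 and compound 2, so no order among the three can be read from it.

Compound 4, `COC(=O)[C@@]1(C)CCC=C2[C@@H]1CC[C@@H](C)[C@]2(C)Cc1c(C)[nH]c2c(Cl)cccc12`, has not yet been measured. It differs from compound 3 in one place: chloro in place of bromo on an aromatic carbon. Among the measured compounds shown here, this is the same kind of change as the one from compound 1 to compound 2, but the surroundings of the place differ: in compound 1 and compound 2 the aromatic carbon is meta to a fused ring and para to a fused ring, whereas in compound 3 and compound 4 it is ortho to a fused ring and meta to a fused ring. Because the step of no change at the digits printed from compound 1 to compound 2 (within the scatter) was flat, the expected step of no change at the digits printed from compound 3 to compound 4 (within the scatter) in this assay is likewise estimated to be small. Compound 4 is therefore expected to give about 25000 nM, estimated to lie between 12000 nM and 50000 nM.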

Compound 4, concentration for 50% growth inhibition: 19000 nM
For compound 4 the middle estimate is 1.3-fold (0.12 log units) above the measured one, within the range that was stated.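

In this assay the exchange of bromo for chloro on the core of compound 3 gives a 1.3-fold lower number from compound 3 to compound 4 (0.12 log units; within the scatter), so on this core too the exchange leaves growth inhibition essentially unchanged. Set beside the same exchange on the core of compound 1, the two steps agree: the same change on two cores in this assay, no change at the digits printed (within the scatter) from compound 1 to compound 2 and a 1.3-fold lower number (0.12 log units; within the scatter) from compound 3 to compound 4, 1.3-fold (0.12 log units) apart, within the scatter of two such steps. This shows that, for these two cores, the flat result of this one exchange carries over from one to the other, whichever of the two aromatic carbons holds the halogen; it does not show that the two cores would respond alike to every change, since both steps lie within the scatter and a flat step offers no sizeable effect whose transfer could be tested, and two pairs in a single assay are too few to support a rule for the whole series.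

The compounds shown leave open whether a group of another kind on these aromatic carbons, such as an amine or a carboxylic acid, would move growth inhibition beyond the scatter at all. They also leave open whether any such shift, once seen on the core of compound 1, would appear to the same extent on the core of compound 3.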